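Halogen versus methoxy substitution on the aryl ketone of a chalcone core

This account rests on a few compounds, and the source may have more. Where it says the series, first, only, none or still open, it means among the compounds named here.

Compound 1 `COc1cc(-c2cc(/C=C/C(=O)c3ccc(Cl)c(Cl)c3)[nH]n2)cc(OC)c1OC`: in a functional assay on Malme-3M cells (Homo sapiens) for inhibition, read by sulforhodamine B assay, with a stated time of 48 h (a lower number here means that less compound is tolerated, a higher number that more compound is tolerated), compound 1 gives only a limit, > 100000 nM.
Compound 2 `COc1ccc(C(=O)/C=C/c2cc(-c3cc(OC)c(OC)c(OC)c3)n[nH]2)cc1OC`: in this assay compound 2 gives 6790 nM.

Going by the values given here, compound 2 is the only compound with a numerical result in this assay; the other value shown is a limit. Among the compounds with values here, the single measured step, an at least 14-fold lower number from compound 1 to compound 2 (1.16 log units; beyond the scatter), is large and runs in the direction of more tolerated compound once the 3,4-dichlorophenyl gives way to 3,4-dimethoxyphenyl on the carbonyl carbon. Compound 3 `COc1cc(-c2cc(/C=C/C(=O)c3ccc(F)c(F)c3)[nH]n2)cc(OC)c1OC` has not yet been measured in this assay. It differs from compound 2 in one place: 3,4-difluorophenyl in place of 3,4-dimethoxyphenyl on a carbonyl carbon. Within the data shown here, the only step that bears on it is the one from compound 1 to compound 2, where a dihalogenated ring on the same carbonyl carbon sat at the limit (the limit of > 100000 nM in this assay, at which 1 of the 2 values shown sits). Going back to a dihalogenated ring is therefore expected to reverse much of that step, giving a higher number for compound 3, with a real chance that only a limit is reported. The estimated step is a 5.9-fold higher number from compound 2 to compound 3 (0.77 log units; beyond the scatter). For compound 3 the expected value in this assay is 40000 nM, in a range from 9000 nM to 150000 nM.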

Compound 3, concentration lethal to 50% of the cells: > 100000 nM
Compound 3: only a limit was reported; the forecaster's own chance of this, stated with the estimate: 40%; middle value at least 2.5-fold (0.39 log units) away from the limit.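

With 3,4-difluorophenyl in place of 3,4-dimethoxyphenyl on the carbonyl carbon, this assay shows an at least 14-fold higher number from compound 2 to compound 3 (1.16 log units; beyond the scatter), so the large change first seen with 3,4-dichlorophenyl at this position is not confined to the chlorine-bearing ring and also appears with a ring carrying fluorine. Among the compounds shown, 3,4-dimethoxyphenyl is now the only group on this carbonyl carbon that gives a number rather than a limit, and the two dihalogenated rings fall together at the same ceiling: the limit of > 100000 nM in this assay, at which 2 of the 3 values shown sit. The step between compound 1 and compound 3 cannot be read, as each gives only a limit, so the chlorine and fluorine rings cannot be placed in any order in this read-out.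

As far as these compounds go, what stays open is whether the number for compound 2 depends on both methoxy groups, on one of them, or simply on the ring carrying no halogen. A ring with a single methoxy group, a hydroxy group or an amine at this position would begin to separate these readings, and an unsubstituted phenyl would give them a reference point.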